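Swapping one aryl group on an inactive scaffold

The source may report more compounds than this note shows. Statements on the series, on what has been measured and on what is new or still open speak of the compounds shown alone.

Compound 1 `COc1cc(C2=C(c3cc(C)c(OC)c(C)c3)C(O)CC2=O)cc(OC)c1OC`: > 100 ug/mL
Compound 2 `COc1cc(C2=C(c3cc(C)c(OC)c(C)c3)C(OC(C)=O)CC2=O)cc(OC)c1OC`: > 100 ug/mL

In an ADME assay on L132 cells (Homo sapiens) for cytotoxicity, read by MTT assay, with a stated time of 72 h (on this read-out higher numbers stand for weaker inhibition and lower numbers for stronger inhibition), compound 2 gives > 100 ug/mL, which is a limit and not a number. Compound 1 gives > 100 ug/mL, also a limit. Compound 3 `COc1ccc(C2=C(c3cc(OC)c(OC)c(OC)c3)C(=O)CC2OC(C)=O)cc1NC=O` differs from compound 2 by one exchange: 3-(formylamino)-4-methoxyphenyl in place of 4-methoxy-3,5-dimethylphenyl on a double-bonded ring carbon. For the measured compounds named here, the sole measured step, a step that the two limits leave unreadable from compound 1 to compound 2, lies elsewhere on the shared core and offers no size to carry over. All that is known is the limit of > 100 ug/mL in this assay, at which 2 of the 2 values shown sit. Going by the values given here, a step towards stronger inhibition is expected in this assay, though no measured step fixes its size. The estimated change is an at least 10-fold lower number from compound 2 to compound 3 (1.00 log units; beyond the scatter). Compound 3 is expected at 10 ug/mL, within an estimated range of 0.3 ug/mL to 100 ug/mL.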

Compound 3, half-maximal inhibitory concentration: 2 ug/mL
For compound 3 the middle estimate is 5.0-fold (0.70 log units) above the measured one, within the range that was stated.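

In this assay, the aryl group on the double-bonded ring carbon proves to be a place where the read-out moves, unlike the acetylation, whose step the two limits leave unreadable. Exchanging 4-methoxy-3,5-dimethylphenyl for 3-(formylamino)-4-methoxyphenyl gives an at least 50-fold lower number from compound 2 to compound 3 (1.69 log units; beyond the scatter). Only compound 3 carries a number rather than a limit: the limit of > 100 ug/mL in this assay, at which 2 of the 3 values shown sit.

The compounds shown do not separate the gain of the formylamino group from the loss of the two methyl groups. On these data alone, whether an amine in place of the formylamino group would keep this step also remains open.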